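This account rests on a few compounds, and the source may have more. Where it says the series, first, only, none or still open, it means among the compounds named here.

Measured so far:
Compound 1 `N#Cc1ccc(C(=O)Nc2ccc(NS(=O)(=O)C(F)(F)F)c(Cl)c2)cc1`: > 250000 nM
Compound 2 `CCS(=O)(=O)Nc1ccc(NC(=O)c2ccc(C#N)cc2)cc1F`: 26400 nM

Within the data shown here, in an ADME assay on HEK293 cells (Homo sapiens) for cytotoxicity, read by MTT assay, with a stated time of 48 h (on this read-out lower numbers stand for stronger inhibition and higher numbers for weaker inhibition), compound 2 gives 26400 nM, the only actual number in the set. Compound 1 returns a limit in this assay, > 250000 nM, and no number. Compound 1 is thus the one that sits at the limit of > 250000 nM in this assay, at which 1 of the 2 values shown sits. Among the measured compounds shown here, no step between two measured compounds is available, so the two values can only be placed side by side: compound 2 yields a number and compound 1 does not.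

Compound 3 `N#Cc1ccc(C(=O)Nc2ccc(NS(=O)(=O)C(F)(F)F)c(F)c2)cc1` is still to be measured. Against compound 2 it shows (trifluoromethyl in place of ethyl on a sulfonyl sulfur). For the measured compounds named here, no measured pair carries this same change, so the size of the step is open. Like compound 3, compound 1 carries the ((trifluoromethyl)sulfonyl)amino group, and compound 1 gave only the limit > 250000 nM. On that basis compound 3 is expected to show weaker inhibition than compound 2, with a real chance of another limit. The expected step is a 3.8-fold higher number from compound 2 to compound 3 (0.58 log units; beyond the scatter). Compound 3 is estimated at 100000 nM, in a range from 30000 nM to 250000 nM.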

Compound 3, half-maximal inhibitory concentration: > 250000 nM
Compound 3 was reported as a limit (the forecaster's own chance of this, stated with the estimate: 40%); middle value at least 2.5-fold (0.39 log units) away from the limit.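

In this assay, trifluoromethyl in place of ethyl on a sulfonyl sulfur now has a readable lower bound, with the rest of compound 2 unchanged: an at least 9.4-fold higher number from compound 2 to compound 3 (0.97 log units; beyond the scatter). The earlier pair could not give this, as compound 1 differs from compound 2 in more than one place. Compound 3 gives a limit and not a number, and the step from compound 1, fluoro in place of chloro on an aromatic carbon, cannot be read, so that swap can be neither credited nor dismissed; the limit now takes in most of the set: the limit of > 250000 nM in this assay, at which 2 of the 3 values shown sit.

As far as these compounds go, the full size of the sulfonyl step stays open, as does any difference between the fluoro and chloro compounds, since neither trifluoromethyl compound has a number in this assay. Also open, from the compounds shown here alone, is where a methyl or a longer chain such as propyl on the sulfonyl sulfur would fall relative to the ethyl of compound 2, and whether any group other than ethyl there gives a number at all.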